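Three weak antiproliferative benzoxazinones and a methoxyphenyl variant

The source may report more compounds than this note shows. Statements on the series, on what has been measured and on what is new or still open speak of the compounds shown alone.

Measured compounds:
Compound 1, `COc1ccc(N2C(=O)COc3ccc(-c4ccc(O)cc4)cc32)cc1`, gives 26100 nM in a functional assay on HCT-116 cells (Homo sapiens) for antiproliferative activity, read by MTT assay, with a stated time of 72 h; a higher number here means a weaker inhibitor, a lower number a stronger inhibitor.
Compound 2, `COc1ncc(-c2ccc3c(c2)NC(=O)CO3)cc1NS(=O)(=O)c1ccc(F)cc1`, gives 24900 nM in this assay.
Compound 3, `O=C1COc2ccc(-c3cccc(NS(=O)(=O)c4ccc(F)cc4)c3)cc2N1c1ccc(Cl)cc1`, gives 23900 nM in this assay.

The three compounds share a fused core carrying an aryl group on the amide-type ring nitrogen and a second aryl group on the aromatic ring of the core. In this assay compound 3 gives 23900 nM, a number that sits together with those of compound 1 and compound 2: the differences between compound 3 and either of them fall within the usual scatter of repeated measurements, so no order among the three can be read from these values. All three are weak inhibitors in this measure.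

Compound 4, `COc1cccc(N2C(=O)COc3ccc(-c4cccc(NS(=O)(=O)c5ccc(F)cc5)c4)cc32)c1`, has not yet been measured. It differs from compound 3 only on the amide-type nitrogen in the ring:

3-methoxyphenyl in place of 4-chlorophenyl on an amide-type nitrogen in a ring

For the measured compounds named here, no pair of measured compounds isolates a change of this kind, so there is no measured step to lean on. Going by the values given here, with three closely similar values as the only guide, the step from compound 3 to compound 4 in this assay is expected to be small, with no clear direction beyond the scatter, and a 1.0-fold higher number from compound 3 to compound 4 (0.02 log units; within the scatter) is the estimate for it. Compound 4 is therefore expected to give about 25000 nM in this assay, within a range from 10000 nM to 60000 nM.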

Compound 4, half-maximal inhibitory concentration: > 40000 nM
Compound 4: no number, only a limit; the forecaster's own chance of this, stated with the estimate: 10%; middle value at least 1.6-fold (0.20 log units) from the limit.
By their numbers in this assay, from the lowest: compounds 3, 2 and 1 (each within the scatter of the next). At a limit, above all of these: compound 4.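

For the compounds shown here, replacing 4-chlorophenyl with 3-methoxyphenyl on the amide-type nitrogen in the ring gives the first measured step at this position, an at least 1.6-fold higher number from compound 3 to compound 4 (0.22 log units; that floor lies within the scatter). The change therefore brings no gain in this assay, but the floor of this step does not establish a difference beyond the usual scatter, and the true size of the step cannot be read. The result for compound 4 is a limit of the assay and not a number: the limit of > 40000 nM in this assay, at which 1 of the 4 values shown sits.

The compounds shown do not separate the removal of the chlorine, the arrival of the methoxy group and the change in where the substituent sits on the phenyl ring, and they give no cause for the result: compound 1 also carries a methoxyphenyl group on this nitrogen but differs from compound 3 elsewhere as well, and compound 2 carries the amide hydrogen there but also differs in more than one place. From the compounds shown here alone, what a plain phenyl, a benzyl group or a short alkyl chain would give on this nitrogen, with the rest of compound 3 kept, also remains open.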